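Trimming an Ethyl to Methyl on the Piperazine Tail

The compounds below may be only part of what the source reports. "The series", "measured", "known", "first", "only" and "open" are said of these compounds alone.

Measured so far:
Compound 1 `COc1cc2c(Oc3c(F)cc(NC(=O)NN4C(=O)C(C)(C)SC4c4c(F)cccc4F)cc3F)ccnc2cc1OCCCN1CCCC1` gives 1450 nM
Compound 2 `COc1cc2c(Oc3c(F)cc(NC(=O)NN4C(=O)CCSC4c4c(F)cccc4F)cc3F)ccnc2cc1OCCCN1CCCC1` gives 400 nM
Compound 3 `CCN1CCN(CCCOc2cc3nccc(Oc4c(F)cc(NC(=O)NN5C(=O)CSC5c5c(F)cccc5F)cc4F)c3cc2OC)CC1` gives 350 nM

In a functional assay on A549 cells (Homo sapiens) for antiproliferative activity, read by MTT assay, with a stated time of 72 h (on this read-out higher numbers stand for weaker inhibition and lower numbers for stronger inhibition), compound 3 has the lowest number of the three. Compound 2 sits within the scatter of it, so no order between the two can be claimed; compound 1 lies beyond the scatter with a higher number, meaning weaker inhibition. Compound 4 `COc1cc2c(Oc3c(F)cc(NC(=O)NN4C(=O)CSC4c4c(F)cccc4F)cc3F)ccnc2cc1OCCCN1CCN(C)CC1` differs from compound 3 in one place only: hydrogen in place of methyl on a saturated chain carbon bound to an amine nitrogen in a ring. Among the measured compounds shown here, no pair among the measured compounds isolates this change, so nothing measured tells how large it is. A change of this kind, far from the rest of the molecule, is expected to give a step no larger than the scatter in this assay, in either direction. Compound 4 is therefore expected to give 350 nM, ranging from 150 nM to 800 nM, an expected step of no change at the digits printed from compound 3 to compound 4 (within the scatter).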

Compound 4, half-maximal inhibitory concentration: 510 nM
The estimate for compound 4 lay 1.5-fold (0.16 log units) below the measured number; the measured number falls inside the stated range.
By their numbers in this assay, from the lowest: compounds 3, 2 and 4 (each within the scatter of the next); then compound 1.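

Among the compounds shown here, compound 3 and compound 4 are the first pair here that isolates the group on the piperazine nitrogen, and in this assay ethyl to methyl gives a 1.5-fold higher number from compound 3 to compound 4 (0.16 log units; within the scatter) on this single change. For the compounds shown here, at this position, then, the two groups cannot be told apart, and removing one carbon from the end of the tail leaves no step that can be read. No measurement at hand gives a reason for this result. From the compounds shown here alone, whether the same holds for a longer chain, such as butyl, on that nitrogen stays open. A 2-hydroxyethyl group or a carboxylic acid at the end of the tail is equally untested among these compounds.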